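Pyridin-2-yl to 1,3-thiazol-2-yl on the series nitrogen

The compounds below may be only part of what the source reports. "The series", "measured", "known", "first", "only" and "open" are said of these compounds alone.

Values so far in a functional assay on SF-268 cells (Homo sapiens) for cytotoxicity, read by MTT assay, with a stated time of 3 days (on this read-out higher numbers stand for weaker inhibition and lower numbers for stronger inhibition), are these:
compound 1 `N#Cc1c(NN)nc(SCc2nc3ccccc3[nH]2)nc1-c1ccccc1` - 2.77 nM
compound 2 `N#Cc1c(Nc2ccccn2)nc(SCc2nc3ccccc3[nH]2)nc1-c1ccccc1` - 6.75 nM

For the measured compounds named here, compound 2 holds the higher of the two numbers and is therefore the weaker inhibitor of the pair, with compound 1 as its only neighbour. The next compound to be read is compound 3 `N#Cc1c(Nc2nccs2)nc(SCc2nc3ccccc3[nH]2)nc1-c1ccccc1`, which differs from compound 2 by one exchange 1,3-thiazol-2-yl in place of pyridin-2-yl on a nitrogen on an aromatic ring in which 1,3-thiazol-2-yl stands in place of pyridin-2-yl on a nitrogen on an aromatic ring. Going by the values given here, one measured step bears on this, namely a 2.4-fold higher number from compound 1 to compound 2 (0.39 log units; beyond the scatter), and it is modest. That step put an aromatic ring in place of amino, whereas here one aromatic ring replaces another, so it is only indirect guidance. Among the compounds with values here, no measured step covers this exchange itself. No step beyond the scatter is therefore expected in this assay, and no direction can be favoured. The expected change is a 1.1-fold lower number from compound 2 to compound 3 (0.05 log units; within the scatter) and would stay small. For compound 3 the estimate is 6 nM, with an expected range from 2.5 nM to 16 nM in this read-out.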

Compound 3, half-maximal inhibitory concentration: 2.55 nM
The estimate for compound 3 lay 2.4-fold (0.37 log units) above the measured number, and the stated range covers the measured number.
By their numbers in this assay, from the lowest: compounds 3 and 1 (each within the scatter of the next); then compound 2.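

In this assay, 1,3-thiazol-2-yl in place of pyridin-2-yl on this nitrogen gives a 2.6-fold lower number from compound 2 to compound 3 (0.42 log units; beyond the scatter), so the choice of aromatic ring at this place changes the number, which the earlier pair, comparing only amino with pyridin-2-yl, could not show. Setting 1,3-thiazol-2-yl against amino gives a 1.1-fold lower number from compound 1 to compound 3 (0.04 log units; within the scatter), so an aromatic ring on this nitrogen does not in itself go with the higher number seen for compound 2, as compound 3 carries such a ring and still lies within the scatter of compound 1. Nothing available accounts for the gap between the two rings.

The exchange from compound 2 to compound 3 alters ring size and the number and kind of hetero atoms together, and these compounds cannot separate those changes. A plain phenyl or a 1,3-oxazol-2-yl on the same nitrogen would help to show whether the ring nitrogen, the sulfur or the five-membered ring goes with the lower number, while an open chain such as methylamino would test whether any ring is needed at this place at all.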